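Series notes: phenyl in place of isobutoxy on the saturated ring carbon

A few compounds are considered here, and "the series" means these few. Any claim that something is new, unique, unknown or untested is made for them only; others in the source may bear on it.

Measured so far in a functional assay on PC-3 cells (Homo sapiens) for inhibition, read by sulforhodamine B assay, with a stated time of 48 h; a higher number here means a weaker inhibitor, a lower number a stronger inhibitor:
compound 1 `CCO[C@H]1C[C@@H](c2coc3ccc(C)cc3c2=O)N(c2ccccc2)O1`: 39000 nM
compound 2 `Cc1ccc2occ([C@@H]3C[C@H](OCC(C)C)ON3c3ccccc3)c(=O)c2c1`: 37700 nM

Among the measured compounds shown here, only one step is measured, a 1.0-fold lower number from compound 1 to compound 2 (0.01 log units; within the scatter), and it lies within the scatter. Compound 2 therefore stands at the lowest of the two numbers, with compound 1 as nearest neighbour and within the scatter of it, so no order between the two can be claimed.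

Compound 3 `Cc1ccc2occ([C@@H]3C[C@H](c4ccccc4)ON3c3ccccc3)c(=O)c2c1` differs from compound 2 by phenyl in place of isobutoxy on a saturated ring carbon. For the measured compounds named here, no measured step swaps the oxygen-linked chain at this carbon for a ring; the single measured step, a 1.0-fold lower number from compound 1 to compound 2 (0.01 log units; within the scatter), only lengthens that chain and shows nothing beyond the scatter. There is thus no basis for expecting a step beyond the scatter in this assay in either direction, and the uncertainty is wide.

Compound 3 is expected to give about 35000 nM in this assay, between 9000 nM and 130000 nM, that is an expected step of a 1.1-fold lower number from compound 2 to compound 3 (0.03 log units; within the scatter).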

Compound 3, half-maximal inhibitory concentration: > 60000 nM
Compound 3: only a limit was reported; the forecaster's own chance of this, stated with the estimate: 15%; middle value at least 1.7-fold (0.23 log units) away from the limit.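

Compound 3 is reported in this assay only as a limit, not as a number: the limit of > 60000 nM in this assay, at which 1 of the 3 values shown sits. Read as floors, phenyl in place of isobutoxy gives an at least 1.5-fold higher number from compound 2 to compound 3 (0.20 log units; that floor lies within the scatter), and phenyl in place of ethoxy gives an at least 1.5-fold higher number from compound 1 to compound 3 (0.18 log units; that floor lies within the scatter). Among the compounds shown here, this is the first change at this saturated ring carbon that removes the oxygen-linked chain and places an aromatic ring there, and it brings no lower number, although neither floor establishes a real loss.

From the compounds shown here alone, how far the true number of compound 3 lies past its limit stays open, so the size of this change remains unknown. Also open, going by these compounds, is whether an amine, a carboxylic acid or a longer chain on this carbon would move the number in this assay beyond the scatter.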